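A Phenoxy-to-Benzyloxy Step on the Shared Core

The source may hold more compounds than are shown below. What is called first, only, known or untested is meant among the compounds shown, and "the series" means these compounds.

Compound 2 `N#Cc1c(-c2ccc(Oc3ccccc3)cc2)ccn2c(CC(F)(F)F)cnc12` gives 186 nM in a functional assay on CHO cells with metabotropic glutamate receptor 2 (Homo sapiens) as the target, read by GTPgammaS binding (on this read-out lower numbers stand for an effect already at smaller amounts and higher numbers for an effect only at larger amounts of compound), the lower of the two numbers found so far; compound 1 `CC(C)(C)c1ccc(-c2ccn3c(CC(F)(F)F)cnc3c2C#N)cc1` gives 447 nM. Within the data shown here, the only known step, a 2.4-fold lower number from compound 1 to compound 2 (0.38 log units; beyond the scatter), concerns a different place on the molecule. Compound 3 `N#Cc1c(-c2ccc(OCc3ccccc3)cc2)ccn2c(CC(F)(F)F)cnc12` carries benzyl in place of phenyl on an oxygen on an aromatic ring. Among the measured compounds shown here, no measured pair bears on this change, so nothing beyond the scatter is expected in this assay, although a modest shift in either direction cannot be excluded. Compound 3 is therefore estimated at about 200 nM, with a range from 70 nM to 600 nM. The expected step is a 1.1-fold higher number from compound 2 to compound 3 (0.03 log units; within the scatter).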

Compound 3, half-maximal effective concentration: 158 nM
Compound 3: the middle estimate sits 1.3-fold (0.10 log units) above what was measured; low and high end bracket the measured number.
By their numbers in this assay, from the lowest: compounds 3 and 2 (each within the scatter of the next); then compound 1.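

In this assay the change from phenoxy to benzyloxy gives a 1.2-fold lower number from compound 2 to compound 3 (0.07 log units; within the scatter) and so leaves the read-out unmoved at this place, on an oxygen on an aromatic ring. Benzyloxy also stands apart from tert-butyl, as phenoxy did, with a 2.8-fold lower number from compound 1 to compound 3 (0.45 log units; beyond the scatter) on the shared core. No evidence is at hand to explain these results.

The compounds shown leave open whether a longer chain between the oxygen and the phenyl ring would read the same. They also do not show what an amine on that chain would do.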